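The source may hold more compounds than are shown below. What is called first, only, known or untested is meant among the compounds shown, and "the series" means these compounds.

Compound 1 `O=C(CSc1ncccn1)N/N=c1/scc(-c2ccc(Br)cc2)n1-c1ccccc1` — in a functional assay on C6 cells (Rattus norvegicus) for cytotoxicity, read by MTT assay, with a stated time of 24 h (on this read-out higher numbers stand for weaker inhibition and lower numbers for stronger inhibition), compound 1 gives > 200 ug/mL, a limit of the assay rather than a number.
Compound 2 `O=C(CSc1ncccn1)N/N=c1/scc(-c2ccc(F)cc2)n1-c1ccccc1` — 110 ug/mL.
Compound 3 `Cc1ccc(-c2cs/c(=N/NC(=O)CSc3ncccn3)n2-c2ccccc2)cc1` — 85 ug/mL.

Of the two numbers, compound 3 holds the smallest; the gap to it is a 1.3-fold lower number from compound 2 to compound 3 (0.11 log units; within the scatter), so the two cannot be told apart. Compound 4 `Cc1ccc(-c2cs/c(=N/NC(=O)CSc3nnnn3C)n2-c2ccccc2)cc1` differs from compound 3 at the sulfur: 1-methyl-1H-tetrazol-5-yl in place of pyrimidin-2-yl on a sulfur. The measured steps, an at least 1.8-fold lower number from compound 1 to compound 2 (0.25 log units; that floor lies within the scatter), an at least 2.3-fold lower number from compound 1 to compound 3 (0.37 log units; beyond the scatter) and a 1.3-fold lower number from compound 2 to compound 3 (0.11 log units; within the scatter), all change the substituent on the other aromatic ring, none the group on the sulfur, so they give no direct guide. Compound 4 is therefore expected to stay near compound 3, with no change at the digits printed from compound 3 to compound 4 (within the scatter), a step no larger than the scatter, and an estimated value of 85 ug/mL (range 40 ug/mL to 180 ug/mL).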

Compound 4, half-maximal inhibitory concentration: 36.3 ug/mL
For compound 4 the middle estimate is 2.3-fold (0.37 log units) above the measured one; the measured number lies below the stated range.
By their numbers in this assay, from the lowest: compound 4; then compounds 3 and 2 (each within the scatter of the next). At a limit, above all of these: compound 1.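

In this assay, the group on the sulfur proves able to shift the read-out on its own: with everything else held fixed, there is a 2.3-fold lower number from compound 3 to compound 4 (0.37 log units; beyond the scatter), and a lower number here stands for stronger inhibition. The earlier compounds shown here changed only the substituent on the other aromatic ring, so they could not show this. Nothing measured here explains the step.

Going by these compounds, whether 1-methyl-1H-tetrazol-5-yl brings the same shift alongside fluoro or bromo remains open. So does the effect of a plain phenyl or a carboxylic acid chain on the sulfur.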